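A few compounds are considered here, and "the series" means these few. Any claim that something is new, unique, unknown or untested is made for them only; others in the source may bear on it.

Working notes on the series. All compounds share one core and differ only in the group on an aromatic carbon of a six-membered aromatic ring of carbon only. Within the data shown here, compound 1 `COc1cc2nc(N3CCN(S(=O)(=O)c4ccc(Br)cc4)CC3)nc(N)c2cc1OC` carries bromo there; in a functional assay on PC-3 cells (Homo sapiens) for inhibition (a lower number here means a stronger inhibitor, a higher number a weaker inhibitor), compound 1 gives 20000 nM, the smallest of the three numbers so far, though both other numbers stand within the scatter of it. Compound 2 `COc1cc2nc(N3CCN(S(=O)(=O)c4ccc([N+](=O)[O-])cc4)CC3)nc(N)c2cc1OC` carries nitro and in this assay compound 2 gives 36000 nM; the step is a 1.8-fold higher number from compound 1 to compound 2 (0.26 log units; within the scatter). Compound 3 `COc1cc2nc(N3CCN(S(=O)(=O)c4ccc(C)cc4)CC3)nc(N)c2cc1OC` carries methyl and in this assay compound 3 gives 30000 nM; the step is a 1.5-fold higher number from compound 1 to compound 3 (0.18 log units; within the scatter), and between the two of them the step is a 1.2-fold lower number from compound 2 to compound 3 (0.08 log units; within the scatter). Compound 4 `COc1cc2nc(N3CCN(S(=O)(=O)c4ccc(OC(F)(F)F)cc4)CC3)nc(N)c2cc1OC` is the next variation at the same place: trifluoromethoxy in place of bromo on an aromatic carbon. Both measured steps away from compound 1 bear on it, and neither left the scatter, so exchanging the group on this aromatic carbon has so far not moved the number beyond the scatter. For compound 4 the expected step is therefore a 1.3-fold higher number from compound 1 to compound 4 (0.10 log units; within the scatter), that is no shift beyond the scatter. Compound 4 is expected to give about 25000 nM in this assay, with a range from 8000 nM to 80000 nM.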

Compound 4, half-maximal inhibitory concentration: 25000 nM
The estimate for compound 4 equals the measured number at the digits printed; measured number inside the range.
By their numbers in this assay, from the lowest: compounds 1, 4, 3 and 2 (each within the scatter of the next).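

In this assay a bigger group at this place, trifluoromethoxy with 5 heavy atoms and 1 hydrogen-bond acceptor against the 1 heavy atom and 0 acceptors of bromo, leaves the number within the scatter of all three earlier compounds (a 1.3-fold higher number from compound 1 to compound 4 (0.10 log units; within the scatter)) and (a 1.2-fold lower number from compound 3 to compound 4 (0.08 log units; within the scatter)) and (a 1.4-fold lower number from compound 2 to compound 4 (0.16 log units; within the scatter)). Among these compounds, with bromo, nitro, methyl and trifluoromethoxy now compared, no step among compounds 1 to 4 leaves the scatter, so neither the exchange of group nor the added heavy atoms give a readable change at this position. No measured evidence bears on this result.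

On these data alone, whether an amine or a carboxylic acid at this aromatic carbon would leave the scatter remains open. Also open, as far as these compounds go, is whether a change elsewhere on the shared core would move the number at all.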